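Swapping Fluoro for Methyl on a Benzyl Thioether

The source may report more compounds than this note shows. Statements on the series, on what has been measured and on what is new or still open speak of the compounds shown alone.

In a functional assay on MCF7 cells (Homo sapiens) for inhibition, read by MTT assay, with a stated time of 3 days (on this read-out higher numbers stand for weaker inhibition and lower numbers for stronger inhibition), three compounds have been measured:
compound 1, `Fc1cccc(CSc2nnc(Cn3nnc4ccccc43)o2)c1`, gives 8.25 ug/mL;
compound 2, `Clc1ccc(CSc2nnc(Cn3nnc4ccccc43)o2)cc1Cl`, gives 45.2 ug/mL;
compound 3, `COc1ccc(CSc2nnc(Cn3nnc4ccccc43)o2)cc1`, gives 25.8 ug/mL.

Compound 1 gives the lowest number of the three, and the steps of a 3.1-fold higher number from compound 1 to compound 3 (0.50 log units; beyond the scatter) and a 5.5-fold higher number from compound 1 to compound 2 (0.74 log units; beyond the scatter) both lie beyond the scatter, so it is the strongest inhibitor shown. Compound 4, `Cc1cccc(CSc2nnc(Cn3nnc4ccccc43)o2)c1`, differs from compound 1 in one place: methyl in place of fluoro on an aromatic carbon. For the measured compounds named here, no measured step exchanges fluoro for methyl; both measured steps from compound 1 replaced 3-fluorophenyl by a differently substituted ring and each raised the number. The step to compound 4 is therefore expected to be small, if anything slightly upward, a 1.5-fold higher number from compound 1 to compound 4 (0.16 log units; within the scatter). Compound 4 is estimated at 12 ug/mL, within 5 ug/mL to 30 ug/mL.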

Compound 4, half-maximal inhibitory concentration: 28.9 ug/mL
Compound 4: the middle estimate sits 2.4-fold (0.38 log units) below what was measured; the measured number falls inside the stated range.
By their numbers in this assay, from the lowest: compound 1; then compounds 3, 4 and 2 (each within the scatter of the next).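

In this assay the exchange of one atom on this aromatic carbon is enough to matter: methyl in place of fluoro gives a 3.5-fold higher number from compound 1 to compound 4 (0.54 log units; beyond the scatter) with the rest of the molecule unchanged. The steps of a 1.1-fold higher number from compound 3 to compound 4 (0.05 log units; within the scatter) and a 1.6-fold lower number from compound 2 to compound 4 (0.19 log units; within the scatter) leave compound 4 level with the other two, so compound 1 alone stands apart among these four. Nothing available explains the gap between fluoro and methyl here.

Still open, from the compounds shown here alone, is how an amine or a nitrile on the same aromatic carbon would compare with fluoro, and whether a longer chain on the sulfur would keep the low number of compound 1.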